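The source may hold more compounds than are shown below. What is called first, only, known or untested is meant among the compounds shown, and "the series" means these compounds.

Measured compounds, cytotoxicity on cultured human cells:

Compound 1 `N#CCCCn1c(Cn2c(=O)n(-c3ccc(C(=O)NC4CC4)cc3)c3ccncc32)cc2cc(Cl)ccc21`: > 50000 nM (a limit).
Compound 2 `CC(C)CCn1c(Cn2c(=O)n(C3CC3)c3ccncc32)nc2ncccc21`: > 100000 nM (a limit).
Compound 3 `CS(=O)(=O)CCCn1c(Cn2c(=O)n(C3COC3)c3ccncc32)cc2cc(Cl)ccc21`: > 50000 nM (a limit).

In an ADME assay on HeLa cells (Homo sapiens) for cytotoxicity, read by ATP content, with a stated time of 3 days (on this read-out higher numbers stand for lower toxicity in this test and lower numbers for higher toxicity in this test), compound 3 gives > 50000 nM, which is a limit of the test rather than a number. Compound 3 sits at the limit of > 50000 nM in this assay, at which 2 of the 3 values shown sit. Compound 1 also sits at that limit. Compound 2 sits at the limit of > 100000 nM in this assay, at which 1 of the 3 values shown sits. Within the data shown here, none of the three values shown is a measured number, so no step between measured compounds can be stated; what the three values show together is that no toxicity was detected for any of them within the range tested.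

Compound 4 `CC(C)n1c(=O)n(Cc2cc3cc(Cl)ccc3n2CCCS(C)(=O)=O)c2cnccc21` differs from compound 3 in one place: isopropyl in place of oxetan-3-yl on an aromatic nitrogen. The rest of the molecule, including the chain on the other ring nitrogen and the chloro-substituted fused system, is kept.

Among the measured compounds shown here, with no measured step in hand, the expectation for compound 4 in this assay is a step of no size beyond the scatter, with the test most likely again reporting only a limit. Compound 4 is estimated at 80000 nM, with a range from 30000 nM to 300000 nM. The step from compound 3 to compound 4 is thus expected to be a step that the limit leaves unreadable from compound 3 to compound 4.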

Compound 4, half-maximal cytotoxic concentration: > 50000 nM
Compound 4: only a limit was reported; the forecaster's own chance of this, stated with the estimate: 85%; the middle value does not contradict the limit.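

In this assay, compound 3 and compound 4 both stand only as limits and not as numbers, so no step can be read between them. Left open is whether isopropyl in place of oxetan-3-yl on an aromatic nitrogen changes the read-out at all, and at what concentration either compound would show toxicity in this assay.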